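Urea series: benzodioxinyl replacement on compound 3

The compounds below may be only part of what the source reports. "The series", "measured", "known", "first", "only" and "open" are said of these compounds alone.

Compound 3 `Cc1ccc(NC(=O)Nc2ccc(C)c(NC(=O)c3ccccc3)c2)cc1C` gives only a limit in a functional assay on A375P cells (Homo sapiens) for antiproliferative activity (on this read-out lower numbers stand for stronger inhibition and higher numbers for weaker inhibition), namely > 30000 nM. Compound 1 `CC(=O)Nc1cc(NC(=O)Nc2ccc3c(c2)OCCO3)ccc1C` likewise reaches only a limit, > 30000 nM. Compound 2 `Cc1ccc(NC(=O)Nc2cc(Cl)cc(Cl)c2)cc1NC(=O)c1ccccc1` gives 259 nM. Among the measured compounds shown here, the single measured step, an at least 110-fold higher number from compound 2 to compound 3 (2.06 log units; beyond the scatter), runs onto (the limit of > 30000 nM in this assay, at which 2 of the 3 values shown sit), so most of the series sits where no number is resolved. Compound 4 `Cc1ccc(NC(=O)Nc2ccc3c(c2)OCCO3)cc1NC(=O)c1ccccc1` differs from compound 3 by 2,3-dihydro-1,4-benzodioxin-6-yl in place of 3,4-dimethylphenyl on an amide-type nitrogen. For the measured compounds named here, no measured step covers this change. Compound 1, which carries the same entering group on its other amide, also stands at its limit. Compound 4 is therefore expected to stay near the limit, with a step that the limit leaves unreadable from compound 3 to compound 4 as the expected step. The estimate for compound 4 in this assay is 40000 nM, within 8000 nM to 200000 nM.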

Compound 4, half-maximal inhibitory concentration: > 30000 nM
Compound 4 gave a limit, no number (the forecaster's own chance of this, stated with the estimate: 75%); the middle value does not contradict the limit.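

In this assay, 2,3-dihydro-1,4-benzodioxin-6-yl in place of 3,5-dichlorophenyl on this amide-type nitrogen gives an at least 110-fold higher number from compound 2 to compound 4 (2.06 log units; beyond the scatter), so a second group now loses the resolved number seen with 3,5-dichlorophenyl. The steps to compound 4 from compound 3 and from compound 1 cannot be read, as all three values are limits. Most of the series now rests there: the limit of > 30000 nM in this assay, at which 3 of the 4 values shown sit.

Still open, on these data alone, is whether an unsubstituted phenyl or a pyridine ring on this nitrogen gives a resolved number. Also open, as far as these compounds go, is how methyl on the carbonyl carbon behaves alongside 3,5-dichlorophenyl.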